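Chlorine joins the carboxyphenyl end of compound 2

This account rests on a few compounds, and the source may have more. Where it says the series, first, only, none or still open, it means among the compounds named here.

Of the compounds shown here, three have so far been measured in an assay on HEK293 cells for positive allosteric modulation of metabotropic glutamate receptor 3 (Rattus norvegicus), read by thallium flux, with a stated time of 2.5 min; a higher number here means a larger maximal response, a lower number a smaller maximal response. Compound 1 `Cc1c(OCCCCOc2ccc(C(=O)O)cc2)ccc(C(=O)CC(C)C)c1C` gives 16.6%, compound 2 `Cc1c(OCCCCOc2cccc(C(=O)O)c2)ccc(C(=O)CC(C)C)c1C` gives 18.3%, and compound 3 `CCCC(=O)c1ccc(OCCCCOc2ccc(C(=O)O)cc2C)c(C)c1O` gives 40.5%. Compound 2 stands second highest of the three: its number is within the scatter of compound 1, while compound 3 lies beyond the scatter above it. Within the data shown here, the only one-place step measured, a number 1.7 percentage points higher from compound 1 to compound 2 (within the scatter), stayed within the scatter. Compound 4 `Cc1c(OCCCCOc2ccc(C(=O)O)c(Cl)c2)ccc(C(=O)CC(C)C)c1C` now carries 4-carboxy-3-chlorophenyl in place of 3-carboxyphenyl on an oxygen on a saturated carbon. Among the measured compounds shown here, the earlier step bears on this change, as it concerns the same carboxyphenyl group; the chlorine has no counterpart among the measured compounds. Because a number 1.7 percentage points higher from compound 1 to compound 2 (within the scatter) was within the scatter, the step of a number 0.3 percentage points lower from compound 2 to compound 4 (within the scatter) is expected to be small. Compound 4 is therefore estimated at 18%, with a range from 8% to 32%.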

Compound 4, largest response reached (reported as percent of maximum), in percent of the reference or control that the assay uses: 12%
Beside the measured number, compound 4's estimate is 6 percentage points above it; measured number inside the range.
By their numbers in this assay, from the lowest: compounds 4, 1 and 2 (each within the scatter of the next); then compound 3.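

Read as one swap, chloro in place of hydrogen on an aromatic carbon, the step in this assay (a number 4.6 percentage points lower from compound 1 to compound 4 (within the scatter)) shows that this ring position carries a chlorine with no change that stands clear of the scatter. The step from the other acid arrangement, 4-carboxy-3-chlorophenyl in place of 3-carboxyphenyl (a number 6.3 percentage points lower from compound 2 to compound 4 (within the scatter)), reads the same way. No evidence is available to explain this result. Going by these compounds, whether a fluoro or a methoxy group at this position would behave alike remains open, as does whether chlorine would matter on the core of compound 3.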